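The source may report more compounds than this note shows. Statements on the series, on what has been measured and on what is new or still open speak of the compounds shown alone.

In an ADME assay on microsomes from liver (Homo sapiens) for metabolic stability (on this read-out higher numbers stand for fast clearance and lower numbers for slow clearance), compound 1 (`Cc1ccc2[nH]c(C(=O)N[C@H]3CN(S(=O)(=O)c4ccccc4)C[C@@H]3C(=O)N[C@H]3CCCNC3)cc2c1`) gives < 3 mL.min-1.g-1 as a limit of the assay and not a number. Within the data shown here, compound 2 (`O=C(N[C@H]1CN(S(=O)(=O)c2ccccc2)C[C@@H]1C(=O)N[C@H]1CCCNC1)c1nnc(-c2ccc(F)cc2)s1`) gives 8.8 mL.min-1.g-1 as the only actual number so far. Compound 3 (`O=C(N[C@H]1CN(S(=O)(=O)c2ccccc2)C[C@@H]1C(=O)N[C@H]1CCCNC1)c1cc(-c2ccccc2Cl)on1`) keeps the shared core and differs from compound 2 only on a carbonyl carbon whose other neighbour is an amide-type nitrogen (a group of 12 heavy atoms (9 carbon, 1 nitrogen, 1 oxygen, 1 chlorine; one five-membered aromatic ring with 2 hetero atoms, one six-membered aromatic ring of carbon only) in place of a group of 12 heavy atoms (8 carbon, 2 nitrogen, 1 fluorine, 1 sulfur; one five-membered aromatic ring with 3 hetero atoms, one six-membered aromatic ring of carbon only), on a carbonyl carbon). Among the measured compounds shown here, one measured step bears on this place, namely an at least 2.9-fold higher number from compound 1 to compound 2 (0.46 log units; beyond the scatter) on the same carbonyl carbon. That single step joins a different pair of groups and gives no direction for the present swap. The expected step in this assay is therefore a 1.0-fold higher number from compound 2 to compound 3 (0.01 log units; within the scatter) and no change beyond the scatter is expected. Compound 3 is estimated at 9 mL.min-1.g-1 with a range from 4 mL.min-1.g-1 to 20 mL.min-1.g-1 as the expected span.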

Compound 3, intrinsic clearance in microsomes: < 3 mL.min-1.g-1
Compound 3 was reported as a limit (the forecaster's own chance of this, stated with the estimate: 10%); middle value at least 3.0-fold (0.47 log units) away from the limit.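

In this assay, the swap on the carbonyl carbon gives an at least 2.9-fold lower number from compound 2 to compound 3 (0.46 log units; beyond the scatter). This place therefore moves the read-out down as well as up, and two groups with the same count of heavy atoms, each holding a five-membered aromatic ring and a six-membered aromatic ring of carbon only, do not read alike. The step joining compound 1 and compound 3 cannot be read, because both ends stop at the same limit of the assay, so how far either compound lies under it stays unknown: the limit of < 3 mL.min-1.g-1 in this assay, at which 2 of the 3 values shown sit.

The swap changes the five-membered aromatic ring and the halogen together, and the compounds shown do not separate the two. From the compounds shown here alone, how a group carrying an amine or a carboxylic acid would read at this place in this assay also remains open.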